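Defining both stereocentres of compound 1

The compounds below may be only part of what the source reports. "The series", "measured", "known", "first", "only" and "open" are said of these compounds alone.

Compound 1 `CC#CC(CC(=O)O)c1ccc(OCC2COc3ccc(Cl)cc3O2)cc1`: 100 nM
Compound 2 `CCOC(CC(=O)O)c1ccc(OCC2COc3ccc(Cl)cc3O2)cc1`: 640 nM
Compound 3 `O=C(O)CC1(c2ccc(OCC3COc4ccc(Cl)cc4O3)cc2)COC1`: 8060 nM

In a functional assay on HEK293 cells for agonist activity at Free fatty acid receptor 1 (Homo sapiens), read by fluorescence and calcium flux, with a stated time of 10 min (on this read-out higher numbers stand for an effect only at larger amounts of compound and lower numbers for an effect already at smaller amounts), compound 1 gives the lowest of the three numbers. Its nearest neighbour is compound 2, with a 6.4-fold higher number from compound 1 to compound 2 (0.81 log units; beyond the scatter), and the furthest is compound 3, with an 81-fold higher number from compound 1 to compound 3 (1.91 log units; beyond the scatter). Compound 4 `CC#C[C@@H](CC(=O)O)c1ccc(OC[C@@H]2COc3ccc(Cl)cc3O2)cc1` keeps every atom and bond of compound 1: the two compounds have the same atoms and bonds; at least one stereo element is drawn with a configuration in one of them and without one in the other: 2 of 2 stereo elements differ; a stereocentre at a saturated chain carbon is drawn without a configuration in compound 1 and S in compound 4; a stereocentre at a saturated ring carbon is drawn without a configuration in compound 1 and R in compound 4. Neither measured step bears on a stereochemical change; both concern replacement of a group on the chain carbon bound to the aromatic ring. If compound 1 was measured as a mixture, the single stereoisomer compound 4 is expected to give the same or a somewhat lower number, a 1.7-fold lower number from compound 1 to compound 4 (0.22 log units; within the scatter), within or just beyond the scatter. The estimate for compound 4 is 60 nM, ranging from 20 nM to 300 nM.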

Compound 4, half-maximal effective concentration: 260 nM
For compound 4 the middle estimate is 4.3-fold (0.64 log units) below the measured one, within the range that was stated.
By their numbers in this assay, from the lowest: compound 1; then compound 4; then compound 2; then compound 3.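

In this assay, among these compounds, there is a 2.6-fold higher number from compound 1 to compound 4 (0.41 log units; beyond the scatter) with no group changed, so configuration alone moves this read-out, whereas the earlier steps all replaced a group. The form with S at the chain carbon and R at the ring carbon therefore does not beat the drawing without configurations, and if compound 1 is a mixture, another stereoisomer would have to give a lower number than compound 4. The only difference between the two compounds is this: the fact that one of compounds 1 and 4 is drawn with a defined configuration and the other without, at the place where they differ

The compounds shown leave open which of the two stereocentres accounts for the step and how the remaining stereoisomers compare. Also open, from the compounds shown here alone, is whether a nitrile in place of prop-1-yn-1-yl would keep the number of compound 4 in this same configuration.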